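This account rests on a few compounds, and the source may have more. Where it says the series, first, only, none or still open, it means among the compounds named here.

Measured so far:
Compound 1 `CNC(=O)/C=C1\CCc2cc(F)c(F)cc21`: 18 mg/kg
Compound 2 `O=C(/C=C1\CCc2ccc(F)cc21)NCc1ccccc1`: 16 mg/kg

Both values come from a functional assay on the whole organism with Rattus norvegicus as the target; on this read-out lower numbers stand for an effect already at smaller amounts and higher numbers for an effect only at larger amounts of compound. Compound 2 at 16 mg/kg stands level with compound 1 at 18 mg/kg, since the two numbers lie within the usual scatter of each other and show no order. The next structure is compound 3 `NC(=O)/C=C1\CCc2ccc(F)cc21`, which has hydrogen in place of benzyl on an amide-type nitrogen.

Within the data shown here, no pair of measured compounds differs in one place only, so the series offers no direct guide to the size of this step. The two structures in hand do differ, yet their values show no separation. On that thin basis, no shift beyond the scatter is expected in this assay, and no direction is favoured with any confidence. The estimated change is a 1.3-fold higher number from compound 2 to compound 3 (0.10 log units; within the scatter), and the range is kept wide to reflect how little is known. For compound 3 the expected value is 20 mg/kg, with an estimated range of 7 mg/kg to 55 mg/kg.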

Compound 3, dose for half-maximal effect: 21 mg/kg
For compound 3 the middle estimate is 1.1-fold (0.02 log units) below the measured one; measured number inside the range.
By their numbers in this assay, from the lowest: compounds 2, 1 and 3 (each within the scatter of the next).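

Among these compounds, the first comparison that differs in one place only, hydrogen in place of benzyl on an amide-type nitrogen, gives a 1.3-fold higher number from compound 2 to compound 3 (0.12 log units; within the scatter) in this assay for this pair. On this pair, the nitrogen therefore accepts the loss of the whole benzyl group, with its six-membered aromatic ring, without any change that can be told from the scatter, so benzyl at this place is not required to keep the read-out at this level. No measurement is available that bears on why the read-out stays level across this change.

A single pair cannot show whether this tolerance extends to other groups on the same nitrogen, such as a longer chain like n-butyl, a chain ending in an amine or a carboxylic acid, or a substituted benzyl group. Compound 1 differs from the others in more than one place, so the contribution of the fluorine substituents on the shared core and of a methyl group on this nitrogen stays unresolved.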